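The source may hold more compounds than are shown below. What is called first, only, known or untested is meant among the compounds shown, and "the series" means these compounds.

Read-out: a functional assay (Platelet, plasma) for inhibition, with Homo sapiens as the target; on this read-out lower numbers stand for stronger inhibition and higher numbers for weaker inhibition
- Compound 1 `N#Cc1cc2c(nc1N1CCC(C(=O)NS(=O)(=O)Cc3cccc(F)c3)CC1)COC2=O` gives 70500 nM
- Compound 2 `CC1(C(=O)NS(=O)(=O)Cc2ccc(Cl)cc2)CCN(c2nc3c(cc2C#N)C(=O)OC3)CC1` gives 3010 nM

Compound 2 has the lower of the two numbers, and the gap to compound 1 lies beyond the scatter. Compound 3 `N#Cc1cc2c(nc1N1CCC(C(=O)NS(=O)(=O)Cc3ccc(Cl)cc3)CC1)COC2=O` differs from compound 2 in one place hydrogen in place of methyl on a saturated ring carbon with hydrogen in place of methyl on a saturated ring carbon. Within the data shown here, no measured step covers this change, so the expectation in this assay is uncertain: a modest rise in the number, towards weaker inhibition, near the edge of the scatter. The expected size is a 2.0-fold higher number from compound 2 to compound 3 (0.30 log units; within the scatter) on this estimate. Compound 3 is estimated at 6000 nM with a range of 1500 nM to 25000 nM expected.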

Compound 3, half-maximal inhibitory concentration: 4420 nM
Beside the measured number, compound 3's estimate is 1.4-fold (0.13 log units) above it; the measured number falls inside the stated range.
By their numbers in this assay, from the lowest: compounds 2 and 3 (each within the scatter of the next); then compound 1.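

In this assay, methyl and hydrogen on the saturated ring carbon, three ring bonds from the ring nitrogen, stand within the scatter of each other, with a 1.5-fold higher number from compound 2 to compound 3 (0.17 log units; within the scatter) as the step. The large step is on the other side of the molecule: a 16-fold lower number from compound 1 to compound 3 (1.20 log units; beyond the scatter) comes with 4-chlorophenyl in place of 3-fluorophenyl on the saturated chain carbon bound to a sulfonyl sulfur. No evidence on hand accounts for either step.

Open, as far as these compounds go, is how an ethyl or a hydroxyl on that ring carbon would read, and how a longer chain would read in place of the saturated chain carbon bound to the sulfonyl sulfur.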